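Benzothiazole ethers: cytotoxicity on breast epithelial cells

The compounds below may be only part of what the source reports. "The series", "measured", "known", "first", "only" and "open" are said of these compounds alone.

Measured compounds
Compound 1 `FC(F)(F)C(F)(F)C(F)(F)C(F)(F)C(F)(F)C(F)(F)CCn1cc(COc2ccccc2-c2nc3ccccc3s2)nn1`: 35100 nM
Compound 2 `FC(F)(F)Oc1ccc(-c2cc(COc3ccccc3-c3nc4ccccc4s3)on2)cc1`: 43900 nM
Compound 3 `Fc1ccccc1-c1cc(COc2ccccc2-c2nc3ccccc3s2)on1`: 42500 nM

The three measured compounds share one core and differ only in the group attached to it. In an ADME assay on MCF-10A cells (Homo sapiens) for cytotoxicity, read by MTT assay, with a stated time of 24 h (a lower number here means a stronger inhibitor, a higher number a weaker inhibitor), compound 1 gives 35100 nM, compound 2 gives 43900 nM and compound 3 gives 42500 nM. Compound 3 thus stands with the other two: its value lies within the scatter of compound 2 and within the scatter of compound 1, so none of the three can be called apart from the others.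

Compound 4 `Clc1ccc(-c2cc(COc3ccccc3-c3nc4ccccc4s3)on2)cc1` is not yet measured. It differs from compound 3 in one place: 4-chlorophenyl in place of 2-fluorophenyl on an aromatic carbon. Within the data shown here, the one measured step that bears on this is the exchange of one aryl group for another at the same place, a 1.0-fold lower number from compound 2 to compound 3 (0.01 log units; within the scatter), which did not move the number. A further exchange of one aryl group for another at that place is therefore expected to leave this assay where it is, with no step beyond the scatter in either direction.

Compound 4 is accordingly estimated at 41000 nM, with a range from 20000 nM to 85000 nM. That estimate means a step of a 1.0-fold lower number from compound 3 to compound 4 (0.02 log units; within the scatter), which is expected to fall within the scatter.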

Compound 4, half-maximal inhibitory concentration: 38800 nM
Beside the measured number, compound 4's estimate is 1.1-fold (0.02 log units) above it, and the stated range covers the measured number.
By their numbers in this assay, from the lowest: compounds 1, 4, 3 and 2 (each within the scatter of the next).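

In this assay, 4-chlorophenyl in place of 2-fluorophenyl on the aromatic carbon next to the ring nitrogen gives a 1.1-fold lower number from compound 3 to compound 4 (0.04 log units; within the scatter) and so leaves the number within the scatter. Chloro in place of trifluoromethoxy on the same aryl group gives a 1.1-fold lower number from compound 2 to compound 4 (0.05 log units; within the scatter) and also stays within the scatter, so the three aryl groups at this position, now including a chlorine-bearing one, cannot be told apart in this assay. No measurement shown here accounts for this flat result.

Going by these compounds, all three aryl groups are phenyl rings bearing a halogen or trifluoromethoxy, so an aryl group carrying an amine or a carboxylic acid remains open. Also open, on these data alone, is whether a saturated group such as a longer alkyl chain at this position would move the number beyond the scatter.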